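The source may report more compounds than this note shows. Statements on the series, on what has been measured and on what is new or still open speak of the compounds shown alone.

Series notes. Compound 1 `CCCCCCC#Cc1cn(C/C=C/CN2C(=O)c3ccccc3C2=O)c(=O)[nH]c1=O` gives 28000 nM in a functional assay on CCRF-CEM cells (Homo sapiens) for antiproliferative activity, read by MTT assay, with a stated time of 3 days; a lower number here means a stronger inhibitor, a higher number a weaker inhibitor. Compound 2 `CCCCCc1ccc(C#Cc2cn(C/C=C\CN3C(=O)c4ccccc4C3=O)c(=O)[nH]c2=O)cc1` gives 102000 nM in this assay, and compound 3 `CCCCC#Cc1cn(C/C=C\CN2C(=O)c3ccccc3C2=O)c(=O)[nH]c1=O` gives 100000 nM. Compound 1 stands lowest of the three, beyond the scatter from both compound 2 and compound 3. For the measured compounds named here, compound 1 and compound 3 differ in two places, the chain on the triple-bonded carbon and the geometry of the double bond in the linker, so their two values are only set side by side and no step is assigned to them. Going by the values given here, the one step that changes a single place is a 1.0-fold lower number from compound 2 to compound 3 (0.01 log units; within the scatter), within the scatter: exchanging a ring for a chain on the triple-bonded carbon left the number where it was.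

The unmeasured compound 4 `CCCCc1ccc(C#Cc2cn(C/C=C/CN3C(=O)c4ccccc4C3=O)c(=O)[nH]c2=O)cc1` differs from compound 1 by 4-butylphenyl in place of hexyl on a triple-bonded carbon. This is the same kind of exchange, chain against ring on the triple-bonded carbon, as that between compound 2 and compound 3, though in the other direction and on the other double-bond geometry. Among the compounds with values here, with that step within the scatter and no other step touching this position, no change beyond the scatter is expected in this assay from compound 1 to compound 4. The estimate for compound 4 is 30000 nM, within 10000 nM to 90000 nM, which is the expected step of a 1.1-fold higher number from compound 1 to compound 4 (0.03 log units; within the scatter).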

Compound 4, half-maximal inhibitory concentration: 31000 nM
Estimate against measurement, compound 4: 1.0-fold (0.01 log units) below; the measured number falls inside the stated range.
By their numbers in this assay, from the lowest: compounds 1 and 4 (each within the scatter of the next); then compounds 3 and 2 (each within the scatter of the next).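

In this assay, for the compounds shown here, a 1.1-fold higher number from compound 1 to compound 4 (0.04 log units; within the scatter) shows that the chain-against-ring exchange on the triple-bonded carbon also stays within the scatter on the other double-bond geometry, where the earlier step, a 1.0-fold lower number from compound 2 to compound 3 (0.01 log units; within the scatter), gave the only reading at this position. The two steps run in opposite directions, with hexyl leaving and 4-butylphenyl entering in the new one, so among these four compounds the position takes a group of 6 heavy atoms without a ring or one of 10 heavy atoms with a six-membered aromatic ring, and neither step moves the number beyond the scatter. No measurement at hand accounts for this insensitivity to the exchange.

All the groups shown at this position are hydrocarbons, so it remains open whether an amine or a carboxylic acid at the end of the chain would leave the number in place as well. No pair shown differs in the geometry of the double bond alone, so the share of that geometry in any difference between the values cannot be read.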